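The compounds below may be only part of what the source reports. "The series", "measured", "known", "first", "only" and "open" are said of these compounds alone.

Measured compounds:
- compound 1 `COc1ccc(-c2nc(C)oc2C(=O)N2CCN(c3cccc(Cl)c3)CC2)cc1` — "not active" (no number reported) in a functional assay on HL-60 cells (Homo sapiens) for inhibition, read by MTT assay, with a stated time of 72 h; on this read-out lower numbers stand for stronger inhibition and higher numbers for weaker inhibition
- compound 2 `Cc1nc(-c2ccc(F)cc2)c(C(=O)N2CCN(c3ccc(C(=O)C(C)C)cc3)CC2)o1` — "not active" (no number reported)
- compound 3 `Cc1nc(-c2ccccc2)c(C(=O)N2CCN(c3cccc(C(N)=O)c3)CC2)o1` — 71 nM

Of the three measured entries only compound 3 carries a number; compound 1 and compound 2 are each reported without one. Compound 2 therefore stands outside the numerical range of the series: no half-maximal inhibitory concentration was assigned to it, and it shares that position with one further entry, compound 1. Among the compounds with values here, no step between two measured compounds is available, so the size of the effect of any single change on this assay remains unmeasured within this set.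

Compound 4 `Cc1nc(-c2ccc(F)cc2)c(C(=O)N2CCN(c3ccc(Cl)cc3)CC2)o1` is not yet measured. It differs from compound 2 in one place: chloro in place of isopropylcarbonyl on an aromatic carbon. Within the data shown here, with no measured step to rest on, the direction of the change from compound 2 cannot be read from the data; both entries that lack a number, compound 1 and compound 2, carry an aryl substituent on the piperazine-bound ring, and compound 4 keeps that pattern. A gain large enough to reach the region of compound 3 is not supported by anything shown.

Compound 4 is expected to give about 6000 nM in this assay, with a range of 1000 nM to 40000 nM, and a reported outcome without a number is considered nearly as likely as a numerical value.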

Compound 4, half-maximal inhibitory concentration: "not active" (no number reported)
No number was reported for compound 4; the estimate stays without a comparison.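

In this assay, within the data shown here, compound 2 gives "not active" (no number reported) and compound 4 gives "not active" (no number reported) so no step between compound 2 and compound 4 can be read. Nothing shown bears on a cause for this outcome. The compounds shown leave open which single change separates compound 3 from the entries without a number.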